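Swapping the sulfoximine for methylsulfonyl: expected hepatic extraction

The compounds below may be only part of what the source reports. "The series", "measured", "known", "first", "only" and "open" are said of these compounds alone.

Measured compounds:
compound 1 `CC[S+]([O-])(=NC)c1ccc(Nc2ncc(C(F)(F)F)c(N[C@@H]3CCC[C@H]3N(C)C)n2)cc1` gives 0.58
compound 2 `CC(C)N=[S+](C)([O-])c1ccc(Nc2ncc(C(F)(F)F)c(N[C@@H]3CCC[C@H]3N(C)C)n2)cc1` gives 0.78
compound 3 `CCN=[S+](C)([O-])c1ccc(Nc2ncc(C(F)(F)F)c(N[C@@H]3CCC[C@H]3N(C)C)n2)cc1` gives 0.54; 0.58; 0.64 (3 entries)

All three share one core and differ only in the group on an aromatic carbon. In an ADME assay on microsomes from liver (Homo sapiens) (on this read-out lower numbers stand for lower hepatic extraction and higher numbers for higher hepatic extraction), compound 2 stands highest of the two single numbers; its nearest neighbour, compound 1, lies lower, the step being a number 0.20 higher from compound 1 to compound 2 (beyond the scatter). Compound 3, with several entries, spans a range that sits at or below compound 1, as the repeated values show (the several entries of compound 3 in this assay, 0.54; 0.58; 0.64 (3 entries)).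

Compound 4 `CN(C)[C@@H]1CCC[C@H]1Nc1nc(Nc2ccc(S(C)(=O)=O)cc2)ncc1C(F)(F)F` is not yet measured. It differs from compound 2 in this way: a group of 4 heavy atoms (1 carbon, 2 oxygen, 1 sulfur; no ring) in place of a group of 7 heavy atoms (4 carbon, 1 nitrogen, 1 oxygen, 1 sulfur; no ring), on an aromatic carbon The methylsulfonyl enters para to a large group.

Within the data shown here, the one measured step, a number 0.20 higher from compound 1 to compound 2 (beyond the scatter), shows that moving from a group of 6 heavy atoms to one of 7 heavy atoms raised the read-out beyond the scatter. The change to compound 4 goes the other way, to a group of 4 heavy atoms, so a downward step is expected, of a size like that step or somewhat larger: a number 0.28 lower from compound 2 to compound 4 (beyond the scatter). Compound 4 is thus estimated at 0.5, expected between 0.35 and 0.65.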

Compound 4, hepatic extraction ratio: < 0.29
Compound 4 ended at the assay's limit (the forecaster's own chance of this, stated with the estimate: 2%); at least 0.21 between middle value and limit.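

In this assay, compound 4 reads < 0.29, which is a limit of the assay and not a number. Replacing either sulfoximine with methylsulfonyl on this aromatic carbon gives a number at least 0.49 lower from compound 2 to compound 4 (beyond the scatter) and a number at least 0.29 lower from compound 1 to compound 4 (beyond the scatter), so the earlier compounds, which varied only the chains on the sulfoximine, had not shown how far down hepatic extraction can go with a change at this place. The leaving and entering groups have equal counts of hydrogen-bond acceptors and neither has a net charge, and nothing shown here gives a cause for the fall.

Still open, going by these compounds, is how far compound 4 lies under its limit. Also open, on these data alone, is whether a sulfonamide or a nitrile at this place would give a similarly low reading.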